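The source may hold more compounds than are shown below. What is called first, only, known or untested is meant among the compounds shown, and "the series" means these compounds.

The three measured compounds, all tested in a functional assay, read by spectrophotometry, with a stated time of 30 min; a lower number here means a stronger inhibitor, a higher number a weaker inhibitor:

Compound 1, `O=c1[nH]c2ccccc2cc1/C=N/O`; in this assay compound 1 gives 118000 nM.
Compound 2, `Cc1ccc2[nH]c(=O)c(/C=N/O)cc2c1`; in this assay compound 2 gives 160000 nM.
Compound 3, `Cc1ccc2[nH]c(=O)c(/C=N/Nc3ccc([N+](=O)[O-])cc3)cc2c1`; in this assay compound 3 gives 109000 nM.

All three values are weak, and each lies within the usual scatter of the others, so no ranking among them can be read from these numbers. Compound 2 and compound 1 share a core and differ by one change, (hydrogen in place of methyl on an aromatic carbon), and that step came to a 1.4-fold lower number from compound 2 to compound 1 (0.13 log units; within the scatter). Compound 3 carries a different group on the same core as compound 2; the difference between the two cores is not broken down here.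

Compound 4, `O=c1[nH]c2ccccc2cc1/C=N/Nc1ccc([N+](=O)[O-])cc1`, has not yet been measured. Going by the values given here, it differs from compound 3 by hydrogen in place of methyl on an aromatic carbon, the same change, at the same place on the ring, as the one between compound 2 and compound 1. Among the compounds shown, this change occurs twice in all, and the one measured instance stayed within the scatter.

The expectation for compound 4 therefore rests on that single earlier step: because the same change produced a 1.4-fold lower number from compound 2 to compound 1 (0.13 log units; within the scatter), compound 4 is expected to sit close to compound 3, with an expected step of a 1.3-fold lower number from compound 3 to compound 4 (0.11 log units; within the scatter). The estimate for compound 4 in this assay is 85000 nM, expected to fall between 35000 nM and 200000 nM.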

Compound 4, half-maximal inhibitory concentration: 170000 nM
The estimate for compound 4 lay 2.0-fold (0.30 log units) below the measured number; the measured number falls inside the stated range.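

In this assay, putting hydrogen in place of the methyl on the aromatic carbon gave a 1.6-fold higher number from compound 3 to compound 4 (0.19 log units; within the scatter). Set beside the first case of this change, the new step does not differ from it by more than repeated measurements of this kind would: the same change on two cores in this assay, a 1.4-fold lower number (0.13 log units; within the scatter) from compound 2 to compound 1 and a 1.6-fold higher number (0.19 log units; within the scatter) from compound 3 to compound 4, 2.1-fold (0.33 log units) apart, within the scatter of two such steps. Going by these compounds alone, this shows that, across the two cores, the change made no difference that this assay can resolve, and the opposite directions of the two steps should not be read as a real effect of the core; it does not show that the change is truly without effect or that it behaves identically on both cores, as a small real effect could lie hidden within the scatter of only two steps.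

The compounds shown carry only methyl or hydrogen at this ring carbon, leaving open whether a chlorine atom, a methoxy group or a longer chain there would give a step beyond the scatter. Going by these compounds, it also remains open whether an amine or a carboxylic acid in place of the nitro group would bring any of these weak values to a clearly lower number.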